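The source may report more compounds than this note shows. Statements on the series, on what has been measured and on what is new or still open speak of the compounds shown alone.

Measured so far in an ADME assay on HepG2 cells (Homo sapiens) for cytotoxicity, read by MTT assay, with a stated time of 72 h; on this read-out lower numbers stand for higher toxicity in this test and higher numbers for lower toxicity in this test:
- compound 1 `O=Cc1ccc(-c2cc(Cl)cn3c([N+](=O)[O-])c(CS(=O)(=O)c4ccccc4)nc23)cc1`: > 31200 nM, a limit
- compound 2 `O=[N+]([O-])c1c(CS(=O)(=O)c2ccccc2)nc2c(-c3cccc(CO)c3)cc(Cl)cn12`: > 25000 nM, a limit

Compound 2 has no numeric value on this read-out, only the limit > 25000 nM (the limit of > 25000 nM in this assay, at which 1 of the 2 values shown sits).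

Compound 3 `O=[N+]([O-])c1c(CS(=O)(=O)c2ccccc2)nc2c(-c3ccccc3CO)cc(Cl)cn12` has the same atoms joined differently: 2-(hydroxymethyl)phenyl in place of 3-(hydroxymethyl)phenyl on an aromatic carbon. The group sits on an aromatic carbon ortho to a fused ring and meta to a chloro group, and only the hydroxymethyl position on the phenyl ring changes.

For the measured compounds named here, the only measured step that bears on this change is a step that the two limits leave unreadable from compound 1 to compound 2, and it gives no readable size. In this assay, no shift beyond the scatter in either direction is therefore expected, so the expected step is a number no higher from compound 2 to compound 3 (the limit leaves the size open).

For compound 3 the estimated value is 25000 nM, with an expected range of 10000 nM to 60000 nM.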

Compound 3, half-maximal cytotoxic concentration: 88000 nM
Beside the measured number, compound 3's estimate is 3.5-fold (0.55 log units) below it, outside the stated range (above it).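

Compound 1 and compound 2 carry only limits in this assay, and the steps from each of them to compound 3 cannot be read. From the compounds shown here alone, it remains open whether 2-(hydroxymethyl)phenyl in place of 3-(hydroxymethyl)phenyl shifts the half-maximal cytotoxic concentration beyond the usual scatter.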